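A few compounds are considered here, and "the series" means these few. Any claim that something is new, unique, unknown or untested is made for them only; others in the source may bear on it.

Measured in an assay on CHO cells for displacement of a labelled ligand from 5-hydroxytryptamine receptor 7 (Homo sapiens), read by scintillation counting, with a stated time of 120 min, tested at 10 uM; on this read-out lower numbers stand for less inhibition and higher numbers for more inhibition at the one concentration tested (going by the name of the read-out):

compound 1, `Fc1ccc(N2CCN(CCCc3c[nH]c4ccc(F)cc34)CC2)c(-c2cccnc2)c1`: 100%
compound 2, `Fc1ccc(N2CCN(CCCc3c[nH]c4ccc(F)cc34)CC2)c(-c2cncnc2)c1`: 90.9%

Both compounds share the same core and differ only in one ring. Among the compounds with values here, only two numbers have been measured, and the gap between them, a number 9.1 percentage points lower from compound 1 to compound 2 (within the scatter), is within the scatter, so compound 2 stands level with compound 1 on these numbers: each of them blocks nearly all of the labelled ligand at the single concentration tested.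

Compound 3, `Fc1ccc(N2CCN(CCCc3c[nH]c4ccc(F)cc34)CC2)c(-c2cc[nH]c2)c1`, has not been measured. It differs from compound 2 in one place: 1H-pyrrol-3-yl in place of pyrimidin-5-yl on an aromatic carbon. Within the data shown here, the only measured step, from compound 1 to compound 2, swapped one six-membered ring for another and did not move the read-out beyond the scatter. Among the measured compounds shown here, no measured step swaps a six-membered ring for a five-membered one, so that change is untested here. With both measured compounds near the top of the scale, the expected step in this assay is a number 6.9 percentage points lower from compound 2 to compound 3 (within the scatter), a small drop that may well stay within the scatter. Compound 3 is therefore expected to give about 84%, with a likely range from 60% to 100%.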

Compound 3, a percentage reported as inhibition, at one concentration (the size of the read-out at that concentration, not a potency): 99.1%
The estimate for compound 3 lay 15.1 percentage points below the measured number; the measured number falls inside the stated range.
By their numbers in this assay, from the lowest: compounds 2, 3 and 1 (each within the scatter of the next).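

In this assay, the position ortho to a large group now accepts a five-membered ring as well as a six-membered one: placing 1H-pyrrol-3-yl there in place of pyrimidin-5-yl gives a step within the scatter (a number 8.2 percentage points higher from compound 2 to compound 3 (within the scatter)), and placing it there in place of pyridin-3-yl does the same (a number 0.9 percentage points lower from compound 1 to compound 3 (within the scatter)). The earlier pair compared only six-membered rings, both with hydrogen-bond acceptors and no donor, whereas the entering ring has one hydrogen-bond donor and no acceptor, so these compounds show that neither this ring size nor this swap of donor for acceptors separates them on this read-out. The data give no explanation for why the three compounds stand level.

From the compounds shown here alone, all three sit near the top of the scale at a single concentration, so whether the three rings truly match in potency at this receptor remains open. Going by these compounds, it also remains open whether this position would keep the same read-out with a group of another kind, such as a carboxylic acid or an amine, in place of an aromatic ring.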